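Valine Ester in Place of Propanoate on the Shared Core

A few compounds are considered here, and "the series" means these few. Any claim that something is new, unique, unknown or untested is made for them only; others in the source may bear on it.

Compound 1 `CCOC(=O)C1=C(S[C@@H]2CN[C@H](C(=O)Nc3cccc(C(=O)OCC)c3)C2)[C@H](C)[C@@H]2[C@@H]([C@@H](C)OC(=O)CC)C(=O)N12` is an ester prodrug of a shared core, and in an ADME assay on the whole organism (plasma, strain Beagle) for pharmacokinetics, with Canis familiaris (Canis lupus familiaris) as the target, read by LC-MS, with a stated time of 8 h, at a dose of 10 mg/kg by the intraduodenal route (on this read-out lower numbers stand for lower exposure and higher numbers for higher exposure at the dose given), compound 1 returns "below limit of detection" (no number reported), so no single number describes where it stands. Compound 3 `C[C@@H](O)[C@H]1C(=O)N2C3=C(S[C@@H]4CN[C@@H](C4)C(=O)Nc4cccc(c4)C(=O)OCc4oc(=O)oc4COC3=O)[C@H](C)[C@H]12` likewise returns "below limit of detection" (no number reported) in this assay, again without a single number. Among the measured compounds shown here, the one compound with a number is compound 2 `COC(=O)C1=C(S[C@@H]2CN[C@H](C(=O)Nc3cccc(C(=O)OC)c3)C2)[C@H](C)[C@@H]2[C@@H]([C@@H](C)O)C(=O)N12`, which carries methyl esters and a free hydroxyl group and gives 403 ng.h/mL in this assay.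

Compound 4 `CCOC(=O)C1=C(S[C@@H]2CN[C@H](C(=O)Nc3cccc(C(=O)OCC)c3)C2)[C@H](C)[C@@H]2[C@@H]([C@@H](C)OC(=O)[C@@H](N)C(C)C)C(=O)N12` differs from compound 1 in one place: 1-amino-2-methylpropyl in place of ethyl on a carbonyl carbon. No step between two measured compounds matches this change, and compound 1 itself offers no number to step from, so the size and direction of the change in this assay cannot be read from the data shown. The expectation rests only on the fact that compound 2 reaches 403 ng.h/mL while compound 1 and compound 3 give no single number, which shows that compounds of this core can reach measurable exposure.

Compound 4 is therefore expected to give about 150 ng.h/mL in this assay, with a range from 20 ng.h/mL to 1000 ng.h/mL, and a real chance that again no number is reported.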

Compound 4, area under the concentration-time curve: "below limit of detection" (no number reported)
Compound 4 has no reported number here, so the estimate cannot be set against anything.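

Among the compounds shown here, compound 1 and compound 4 both come without a single number, so no step between them can be read. Nothing at hand bears on why compound 4 gives this result. The compounds shown leave open whether 1-amino-2-methylpropyl in place of ethyl changes exposure on the shared core, and in which direction.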